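The source may hold more compounds than are shown below. What is called first, only, known or untested is meant among the compounds shown, and "the series" means these compounds.

The measured compounds, with their results in a functional assay on the whole organism for inhibition, with Rattus norvegicus as the target, read by paw edema, with a stated time of 3 h, at a dose of 50 mg/kg; on this read-out higher numbers stand for more inhibition at the one dose given (going by the name of the read-out) and lower numbers for less inhibition:
compound 1 `CC(=O)c1c(NNc2ccc(C)cc2)cc(C)oc1=O` gives 59.6%;
compound 2 `CC(=O)c1c(NNc2ccc(Cl)cc2)cc(C)oc1=O` gives 58.6%;
compound 3 `Cc1ccc(-n2nc3cc(C)oc(=O)c3c2C)cc1` gives 54%.

Compound 1 and compound 2 share a core and differ in one place: chloro in place of methyl on an aromatic carbon. That change made a step of a number 1 percentage points lower from compound 1 to compound 2 (within the scatter), so the two numbers cannot be told apart. Compound 3 is built on a different core; the difference between the two cores is not broken down here. Its number sits close to those of compound 1 and compound 2, all three within the scatter of each other, so no order among them can be claimed.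

Compound 4 `Cc1cc2nn(-c3ccc(Cl)cc3)c(C)c2c(=O)o1` has not yet been measured in this assay. Within the data shown here, it differs from compound 3 by chloro in place of methyl on an aromatic carbon, the same change as the one from compound 1 to compound 2, made at the same place. Because that earlier change gave a number 1 percentage points lower from compound 1 to compound 2 (within the scatter), a step of similar size is expected here: a number 1 percentage points lower from compound 3 to compound 4 (within the scatter). Compound 4 is therefore estimated at 53%, likely between 43% and 63%.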

Compound 4, a percentage reported as inhibition, in the whole organism at one dose (the size of the read-out at that dose, not a potency): 56.6%
Estimate against measurement, compound 4: 3.6 percentage points below; low and high end bracket the measured number.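

In this assay, chloro in place of methyl on an aromatic carbon gave a number 2.6 percentage points higher from compound 3 to compound 4 (within the scatter). Set beside the earlier case, the two steps cannot be told apart, so on these two cores the change carries over with no difference that this read-out can detect: the same change on two cores in this assay, a number 1 percentage points lower (within the scatter) from compound 1 to compound 2 and a number 2.6 percentage points higher (within the scatter) from compound 3 to compound 4, 3.6 percentage points apart, within the scatter of two such steps. Among these compounds, this does not show that the swap would leave the number unmoved on every core, since only two pairs are available, and both steps lie within the scatter, so even their direction cannot be read.

The compounds shown carry only methyl or chloro at this place, so it stays open whether an amine, a carboxylic acid or a longer chain there would move the number beyond the scatter on either core. As far as these compounds go, it also stays open whether the two cores would respond alike at other doses or other times, since each result here is a single reading at one dose and gives no potency.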